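Swapping trifluoromethyl for chloro on the urea-bearing aryl group

The source may hold more compounds than are shown below. What is called first, only, known or untested is meant among the compounds shown, and "the series" means these compounds.

Of the compounds shown here, two sharing one core have been tested in a functional assay on SK-MEL-5 cells (Homo sapiens) for inhibition, read by sulforhodamine B assay, with a stated time of 48 h, tested at 10 uM; a higher number here means a weaker effect of the compound at the concentration tested, a lower number a stronger effect. Compound 1, `COc1cc2cc(Oc3ccc(NC(=O)Nc4ccc(C)cc4)cc3)c(C)nc2cc1OC`, gives 100% in this assay. Compound 2, `COc1cc2cc(Oc3ccc(NC(=O)Nc4ccc(Cl)c(C(F)(F)F)c4)cc3)c(C)nc2cc1OC`, gives -73.4% in this assay, the lowest of the two numbers and therefore the stronger effect seen so far. For the measured compounds named here, the only measured step, a number 173.4 percentage points lower from compound 1 to compound 2 (beyond the scatter), replaced the whole aryl group on the urea nitrogen, so it bears on the new change only loosely.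

Compound 3, `COc1cc2cc(Oc3ccc(NC(=O)Nc4ccc(Cl)c(Cl)c4)cc3)c(C)nc2cc1OC`, differs from compound 2 by chloro in place of trifluoromethyl on an aromatic carbon. The chloro group already present is kept, and only its neighbour on that ring changes. Going by the values given here, no measured step tells how much of the large gain from compound 1 to compound 2 rests on the trifluoromethyl itself rather than on the chloro, so a small shift in either direction, most likely within the scatter, is expected. Compound 3 is estimated at -45%, with a range from -85% to 5%, meaning an expected step of a number 28.4 percentage points higher from compound 2 to compound 3 (beyond the scatter).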

Compound 3, a percentage reported as activity, at one concentration (the size of the read-out at that concentration, not a potency): -35%
Beside the measured number, compound 3's estimate is 10 percentage points below it; low and high end bracket the measured number.
By their numbers in this assay, from the lowest: compound 2; then compound 3; then compound 1.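

Replacing trifluoromethyl with chloro at this position, ortho to a chloro group, is not a neutral exchange in this assay: it gives a number 38.4 percentage points higher from compound 2 to compound 3 (beyond the scatter), so the effect at the concentration tested weakens. Even so, most of the drop in a number 173.4 percentage points lower from compound 1 to compound 2 (beyond the scatter) is retained with the 3,4-dichlorophenyl group, which gives a number 135 percentage points lower from compound 1 to compound 3 (beyond the scatter). The trifluoromethyl group is therefore not needed for a large part of the effect, although in this pair it gives the lower number. The data shown offer no independent measurement that would explain the difference between these two groups.

The compounds shown cannot separate the contribution of the retained chloro group from that of its neighbour, as no compound here carries a hydrogen at the position that changed. Going by these compounds, it also remains open how other groups at this position, such as methoxy, nitrile or a dimethylamino group, would compare with chloro and trifluoromethyl in this assay.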